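A methyl for a chloro: what to expect

The source may report more compounds than this note shows. Statements on the series, on what has been measured and on what is new or still open speak of the compounds shown alone.

In a functional assay on HCT-116 cells (Homo sapiens) for cytotoxicity, read by sulforhodamine B assay, with a stated time of 48 h (a higher number here means a weaker inhibitor, a lower number a stronger inhibitor), compound 1 `Cc1ccc(-c2c(S(=O)(=O)c3ccccc3)cnc3cc(-c4ccccc4)nn23)cc1` gives 18 ug/mL and compound 2 `Cc1ccc(-c2c(S(=O)(=O)c3ccccc3)cnc3cc(-c4ccc(Cl)cc4)nn23)cc1` gives 9.3 ug/mL as its reading. These two numbers lie within the usual scatter of each other, so compound 2 stands level with compound 1. Compound 3 `Cc1ccc(-c2cc3ncc(S(=O)(=O)c4ccccc4)c(-c4ccc(C)cc4)n3n2)cc1` keeps the shared core and differs from compound 2 in a single group. The swap methyl in place of chloro on an aromatic carbon puts methyl in place of chloro on an aromatic carbon, para to a large group. Going by the values given here, one measured step bears on this carbon, chloro in place of hydrogen, and it gave a 1.9-fold lower number from compound 1 to compound 2 (0.29 log units; within the scatter) as its size. Among the compounds with values here, no measured compound yet carries methyl there, so no step beyond the scatter is expected in this assay for this swap. The estimated step is a 1.4-fold higher number from compound 2 to compound 3 (0.15 log units; within the scatter) and stays within that scatter. For compound 3 the expected value is 13 ug/mL with a range from 6 ug/mL to 26 ug/mL as its likely span.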

Compound 3, half-maximal inhibitory concentration: 10.5 ug/mL
Compound 3: the middle estimate sits 1.2-fold (0.09 log units) above what was measured; the measured number falls inside the stated range.
By their numbers in this assay, from the lowest: compounds 2, 3 and 1 (each within the scatter of the next).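

In this assay, going from 4-chlorophenyl to 4-methylphenyl gives a small step (a 1.1-fold higher number from compound 2 to compound 3 (0.05 log units; within the scatter)), so chloro and methyl at this carbon cannot be told apart by this reading. The comparison with hydrogen adds a second view of the same carbon (a 1.7-fold lower number from compound 1 to compound 3 (0.23 log units; within the scatter)): like chloro, methyl gives a step that cannot be separated from the scatter, so across compound 1, compound 2 and compound 3, none of these three substituents stands out from the others. Nothing available here offers an explanation for these readings.

Still open, from the compounds shown here alone, is whether a different kind of group on this carbon, such as an amine, a carboxylic acid or a longer alkyl chain, would give a step beyond the scatter. Also open, going by these compounds, is whether these three compounds would stay level on other cell types.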